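The compounds below may be only part of what the source reports. "The series", "measured", "known", "first", "only" and "open" are said of these compounds alone.

Compound 2 `N#CC1=C(NCC(=O)O)N(c2ccccc2)C(=O)N2CCCCC(N3CCCC3)C12` gives the highest of the three results in a functional assay on the whole organism (strain albino) for inhibition, with Rattus norvegicus as the target, read by paw edema, with a stated time of 1 h, at a dose of 20 mmol/kg by the intraperitoneal route (on this read-out higher numbers stand for more inhibition at the one dose given (going by the name of the read-out) and lower numbers for less inhibition), at 67.2%. Its nearest neighbour is compound 3 `N#CC1=C(/N=C/c2ccccc2)N(c2ccccc2)C(=O)N2CCCCC(N3CCCC3)C12`, which gives 46.5%; furthest is compound 1 `N#CC1=C(NCN2CCCC2)N(c2ccccc2)C(=O)N2CCCCC(N3CCCC3)C12`, at 22.9%. The untested compound 4 `N#CC1=C(/N=C/Nc2ccccc2)N(c2ccccc2)C(=O)N2CCCCC(N3CCCC3)C12` differs from compound 2 by a group of 9 heavy atoms (7 carbon, 2 nitrogen; one six-membered aromatic ring of carbon only) in place of a group of 5 heavy atoms (2 carbon, 1 nitrogen, 2 oxygen; no ring), on a double-bonded ring carbon. The closest guide is the step of a number 20.7 percentage points lower from compound 2 to compound 3 (beyond the scatter), where an aromatic-ring group likewise replaced the carboxy chain at the same double-bonded ring carbon; the step of a number 44.3 percentage points higher from compound 1 to compound 2 (beyond the scatter) shows that losing the carboxy group goes with a large loss. A modest drop beyond the scatter is therefore expected, estimated as a number 20.2 percentage points lower from compound 2 to compound 4 (beyond the scatter). Compound 4 is expected to give about 47%, within 30% to 64%.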

Compound 4, a percentage reported as inhibition, in the whole organism at one dose (the size of the read-out at that dose, not a potency): 35.2%
Compound 4: the middle estimate sits 11.8 percentage points above what was measured; low and high end bracket the measured number.
By their numbers in this assay, from the lowest: compound 1; then compound 4; then compound 3; then compound 2.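

In this assay, anilino in place of phenyl on the carbon with a double bond to nitrogen gives a number 11.3 percentage points lower from compound 3 to compound 4 (beyond the scatter) and so shows that the result still shifts when only the group on that carbon changes. The new group still gives a number 12.3 percentage points higher from compound 1 to compound 4 (beyond the scatter) but also a number 32 percentage points lower from compound 2 to compound 4 (beyond the scatter) and leaves the (carboxymethyl)amino group of compound 2 ahead of both aromatic-ring groups. No measurement here explains these differences.

Still open, going by these compounds, is whether a longer chain ending in a carboxylic acid would match the (carboxymethyl)amino group, and whether its methyl ester would keep the result.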